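Permeability notes: open chain in place of small ring

This account rests on a few compounds, and the source may have more. Where it says the series, first, only, none or still open, it means among the compounds named here.

Three compounds of the series have numbers in an ADME assay on Caco-2 cells (Homo sapiens) for permeability, read by LC-MS, in the apical to basolateral direction, with a stated time of 60 min, at pH 6.5; a higher number here means that the compound crosses the layer faster, a lower number that the compound crosses the layer more slowly. Compound 1 `CC(C)(C)[C@@H](O)C(=O)N1CSC[C@H]1C(=O)NCc1cc(Cl)ccc1-n1cnnn1` gives 19 10^-6 cm/s. Compound 2 `CC(C)(C)C[C@@H](O)C(=O)N1[C@@H]2C[C@@H]2C[C@H]1C(=O)NCc1cc(Cl)ccc1-n1cnnn1` gives 24 10^-6 cm/s. Compound 3 `CC1(C[C@@H](O)C(=O)N2N=CC[C@H]2C(=O)NCc2cc(Cl)ccc2-n2cnnn2)CC1` gives 9.5 10^-6 cm/s, the lowest number of the three: its gap to compound 1 lies within the scatter, its gap to compound 2 lies beyond it, so only compound 2 is separated from compound 3 with any confidence.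

Compound 4 `CC(C)CC[C@@H](O)C(=O)N1N=CC[C@H]1C(=O)NCc1cc(Cl)ccc1-n1cnnn1` is not yet measured. It differs from compound 3 in one place: isobutyl in place of 1-methylcyclopropyl on a saturated chain carbon, two bonds along the chain from a carbonyl carbon and an oxygen on a saturated carbon. The rest of the structure is unchanged.

Among the compounds with values here, no pair of the measured compounds differs in a single place, so no measured step guides this one. The change exchanges one group for another of the same heavy-atom count, with no donors or acceptors added or removed. On that basis the step in this assay is expected to be small, in either direction, and not beyond the scatter; the expected step is a 1.3-fold higher number from compound 3 to compound 4 (0.10 log units; within the scatter). Compound 4 is expected to give about 12 10^-6 cm/s, in the range 6 10^-6 cm/s to 24 10^-6 cm/s.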

Compound 4, apparent permeability: 29 10^-6 cm/s
Estimate against measurement, compound 4: 2.4-fold (0.38 log units) below; measured number above the stated range.
By their numbers in this assay, from the lowest: compounds 3, 1, 2 and 4 (each within the scatter of the next, the first and the last beyond it).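

In this assay, isobutyl in place of 1-methylcyclopropyl gives a 3.1-fold higher number from compound 3 to compound 4 (0.48 log units; beyond the scatter), so this position on the chain responds to a change that leaves the heavy-atom count and the donor and acceptor counts as they were. Within the data shown here, this is the first step with only one place changed, and it lies beyond the scatter; the earlier compounds differ from one another in more than one place and could not isolate this position. Nothing measured here accounts for the size of the step.

Going by these compounds, one step cannot separate the loss of the three-membered ring from other differences between the two groups, and whether it carries over to the cores of compound 1 and compound 2 remains open. On these data alone, how a longer straight chain or an amine at this place would read in this assay also remains open.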